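This account rests on a few compounds, and the source may have more. Where it says the series, first, only, none or still open, it means among the compounds named here.

Measured in a functional assay on SMMC-7721 cells (Homo sapiens) for inhibition, read by MTT assay, with a stated time of 48 h; on this read-out lower numbers stand for stronger inhibition and higher numbers for weaker inhibition:
- Compound 1 `CN(c1ncccc1CNc1nc(Nc2ccc3c(c2)CC(=O)N3)nc2[nH]cc(C#N)c12)S(C)(=O)=O`: > 100000 nM (a limit)
- Compound 2 `CN(c1ncccc1CNc1nc(Nc2ccccc2)nc2[nH]cc(F)c12)S(C)(=O)=O`: > 100000 nM (a limit)
- Compound 3 `COc1ccc(Nc2nc(NCc3cccnc3N(C)S(C)(=O)=O)c3c(F)c[nH]c3n2)cc1OC`: 54800 nM

Compound 2 gives > 100000 nM in this assay, and this is a limit, not a measured number. Within the data shown here, it is not alone there, as the series so far largely rests on (the limit of > 100000 nM in this assay, at which 2 of the 3 values shown sit). Any step that starts from compound 2 therefore starts from an unknown point.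

Compound 4 `CN(c1ncccc1CNc1nc(Nc2cccc(CN)c2)nc2[nH]cc(F)c12)S(C)(=O)=O` keeps all of compound 2 except for one change: aminomethyl in place of hydrogen on an aromatic carbon. In words, this is aminomethyl in place of hydrogen on an aromatic carbon, so that phenyl becomes 3-(aminomethyl)phenyl.

Among the measured compounds shown here, only one measured step touches the same phenyl, and it brings in a different group: an at least 1.8-fold lower number from compound 2 to compound 3 (0.26 log units; that floor lies within the scatter). Compound 1 differs from compound 2 in more than one place, so it offers no clean comparison. For the measured compounds named here, with compound 3 at 54800 nM as the only real number, the evidence is thin. It supports only a modest expectation: a small move toward lower numbers, or none beyond the scatter, with a real chance that compound 4 also ends at a limit.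

The estimated change is an at least 1.6-fold lower number from compound 2 to compound 4 (0.22 log units; that floor lies within the scatter). The expected value for compound 4 is 60000 nM, with an estimated range of 15000 nM to 150000 nM.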

Compound 4, half-maximal inhibitory concentration: > 100000 nM
Compound 4: only a limit was reported; the forecaster's own chance of this, stated with the estimate: 45%; middle value at least 1.6-fold (0.22 log units) away from the limit.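

In this assay compound 4 gives > 100000 nM, which is a limit and not a number, so adding aminomethyl to this phenyl does not yield a measurable value here. Among these compounds, the steps that start from compound 2 cannot be read, as both ends are limits, while the one readable step, with 3-(aminomethyl)phenyl in place of 3,4-dimethoxyphenyl, is an at least 1.8-fold higher number from compound 3 to compound 4 (0.26 log units; that floor lies within the scatter), which sets no firm order between the two groups. Compound 3 thus remains the only compound with a real number, and the series now leans even more heavily on a single ceiling: the limit of > 100000 nM in this assay, at which 3 of the 4 values shown sit.

The compounds shown leave open whether any other group at this place on the phenyl, such as a hydroxyl, a carboxylic acid or a longer chain like 2-aminoethyl, would give a real number in this assay. On these data alone, they also leave open the true values of compound 2 and compound 4, so it is unknown whether aminomethyl in place of hydrogen on an aromatic carbon changes anything at all.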